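A few compounds are considered here, and "the series" means these few. Any claim that something is new, unique, unknown or untested is made for them only; others in the source may bear on it.

Measured so far in a functional assay on OE21 cells (Homo sapiens) for inhibition, read by MTT assay, with a stated time of 72 h; a higher number here means a weaker inhibitor, a lower number a stronger inhibitor:
- compound 2 `O=C(NNc1nncc2ccccc12)C1CC1c1ccc(OCC(F)(F)F)cc1`: 17000 nM
- compound 3 `O=C(NNC(=O)C1CC1c1ccc(OCC(F)(F)F)cc1)c1ccncc1`: 31000 nM
- compound 1 `O=C(NNC(=O)C1CC1c1ccc(OC(F)(F)F)cc1)c1ccncc1`: "not determined" (no result reported)

Within the data shown here, only two numbers exist in this assay, and they lie within the scatter of one another: compound 2 with 17000 nM and compound 3 with 31000 nM cannot be told apart on these data. Compound 1 shares the hydrazide linkage and the cyclopropane of compound 3 but gives no result in this assay, so it adds nothing to the comparison. Both measured numbers sit in a weak range for this assay.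

Compound 4 `CC(C)=CCOc1ccc(C2CC2C(=O)NNc2nncc3ccccc23)cc1` differs from compound 2 in one place: 2-methylprop-1-en-1-yl in place of trifluoromethyl on a saturated chain carbon bound to an oxygen on an aromatic ring, the 2-methylprop-1-en-1-yl taking the place of the trifluoromethyl on a saturated chain carbon bound to an oxygen on the aromatic ring. Among the measured compounds shown here, no pair of measured compounds shows the effect of a change at this position, so no measured step can be carried over.

With nothing in the series to support a large move, the expectation is a step within the scatter, a 1.1-fold lower number from compound 2 to compound 4 (0.05 log units; within the scatter), with no clear direction. Compound 4 is estimated at 15000 nM in this assay, between 5000 nM and 50000 nM.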

Compound 4, half-maximal inhibitory concentration: 38000 nM
Compound 4: middle estimate off by 2.5-fold (0.40 log units), on the low side, within the range that was stated.
By their numbers in this assay, from the lowest: compounds 2, 3 and 4 (each within the scatter of the next, the first and the last beyond it).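

Among these compounds, the first measured step at this position comes from replacing trifluoromethyl with 2-methylprop-1-en-1-yl on a saturated chain carbon bound to an oxygen on an aromatic ring: in this assay this gives a 2.2-fold higher number from compound 2 to compound 4 (0.35 log units; beyond the scatter) and is a modest move. The groups count the same heavy atoms, and neither carries a hydrogen-bond donor or acceptor, yet the number still shifts, so this position is not indifferent to the change, at least in this single pair on the core of compound 2. Nothing available explains the shift.

With one pair, the step cannot be assigned to the loss of fluorine, the double bond or the branching, and a saturated 3-methylbutyl chain, an ethyl chain or a chain ending in an amine or a carboxylic acid would help separate these. Going by these compounds, it also remains open whether the same replacement gives a step of similar size on the hydrazide linkage shared by compound 1 and compound 3.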